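The compounds below may be only part of what the source reports. "The series", "measured", "known", "first", "only" and "open" are said of these compounds alone.

compound 1 `CN1CCN(CCCCn2c3c(c4ccccc42)C(=O)c2c[n+]([O-])c4ccccc4c2C3=O)CC1` gives 30 nM
compound 2 `O=C1c2c[n+]([O-])c3ccccc3c2C(=O)c2c1c1ccccc1n2CCCCN1CCNCC1` gives 460 nM
compound 3 `CN1CCN(CCCCCCn2c3c(c4ccccc42)C(=O)c2c[n+]([O-])c4ccccc4c2C3=O)CC1` gives 630 nM

All three values come from a functional assay on A-375 cells (Homo sapiens) for cytotoxicity, read by MTT assay, with a stated time of 72 h (on this read-out lower numbers stand for stronger inhibition and higher numbers for weaker inhibition), and compound 2 sits level with compound 3, given a 1.4-fold higher number from compound 2 to compound 3 (0.14 log units; within the scatter) and clearly apart from compound 1, given a 15-fold higher number from compound 1 to compound 2 (1.19 log units; beyond the scatter) as the gap.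

Compound 4 `O=C1c2c[n+]([O-])c3ccccc3c2C(=O)c2[nH]c3ccccc3c21` differs from compound 2 by hydrogen in place of 4-(piperazin-1-yl)butyl on an aromatic nitrogen with hydrogen in place of 4-(piperazin-1-yl)butyl on an aromatic nitrogen. For the measured compounds named here, no measured step removes the whole side chain. The nearest evidence is a 15-fold higher number from compound 1 to compound 2 (1.19 log units; beyond the scatter) and a 21-fold higher number from compound 1 to compound 3 (1.32 log units; beyond the scatter) for edits within that side chain, both large, so a sizeable shift is possible, but its direction is poorly supported. A moderate step to a higher number is tentatively expected in this assay for this change. The estimate corresponds to a 2.2-fold higher number from compound 2 to compound 4 (0.34 log units; beyond the scatter) as the expected step. Compound 4 is expected at about 1000 nM within an estimated range of 180 nM to 5000 nM in this read-out.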

Compound 4, half-maximal inhibitory concentration: 660 nM
Compound 4: middle estimate off by 1.5-fold (0.18 log units), on the high side, and the stated range covers the measured number.
By their numbers in this assay, from the lowest: compound 1; then compounds 2, 3 and 4 (each within the scatter of the next).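

In this assay, the full 4-(piperazin-1-yl)butyl on the aromatic nitrogen and plain hydrogen cannot be told apart, with a 1.4-fold higher number from compound 2 to compound 4 (0.16 log units; within the scatter). Among the side chains on this nitrogen, the 4-(4-methylpiperazin-1-yl)butyl chain stands clearly apart from hydrogen, with a 22-fold higher number from compound 1 to compound 4 (1.34 log units; beyond the scatter), while the chain without the methyl does not. No evidence is available to explain this difference.

Still open, on these data alone, is whether a propyl chain carrying the same 4-methylpiperazin-1-yl would keep the number of compound 1. A morpholine in place of the methylpiperazine is equally untested by these compounds.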